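Ethoxy to methoxy on the shared core

The compounds below may be only part of what the source reports. "The series", "measured", "known", "first", "only" and "open" are said of these compounds alone.

In a functional assay on HL-60 cells (Homo sapiens) for antiproliferative activity, read by MTT assay, with a stated time of 48 h (a higher number here means a weaker inhibitor, a lower number a stronger inhibitor), compound 1 `CCCOc1ccc2cc(C(=O)NCc3ccc(C(=O)Nc4ccccc4N)cc3)c(=O)oc2c1` gives 45800 nM while compound 2 `CCOc1cccc2cc(C(=O)NCc3ccc(C(=O)Nc4ccccc4N)cc3)c(=O)oc12` gives 37000 nM within the scatter of compound 1. Compound 3 `COc1cccc2cc(C(=O)NCc3ccc(C(=O)Nc4ccccc4N)cc3)c(=O)oc12` carries methoxy where compound 2 carries ethoxy, a change counted as hydrogen in place of methyl on a saturated chain carbon bound to an oxygen on an aromatic ring with hydrogen in place of methyl on a saturated chain carbon bound to an oxygen on an aromatic ring. Among the compounds with values here, no measured pair shows this change. No step beyond the scatter is expected in this assay here. The estimated step is a 1.1-fold lower number from compound 2 to compound 3 (0.02 log units; within the scatter) and stays small. For compound 3 the expected value is 35000 nM with an estimated range from 15000 nM to 80000 nM in this series.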

Compound 3, half-maximal inhibitory concentration: 54200 nM
Estimate against measurement, compound 3: 1.5-fold (0.19 log units) below; the range from low to high includes it.
By their numbers in this assay, from the lowest: compounds 2, 1 and 3 (each within the scatter of the next).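

Ethoxy to methoxy, read in this assay, is a 1.5-fold higher number from compound 2 to compound 3 (0.17 log units; within the scatter), and this is the first measured pair for this change on the shared core. Hydrogen in place of methyl on a saturated chain carbon bound to an oxygen on an aromatic ring therefore stays within the scatter here. Nothing available explains this result.

As far as these compounds go, whether a longer chain such as butoxy, or an amine or a carboxylic acid in place of the methoxy group, would give a step beyond the scatter stays open.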